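Swapping the Outer Ring on Two Benzimidazole Cores

A few compounds are considered here, and "the series" means these few. Any claim that something is new, unique, unknown or untested is made for them only; others in the source may bear on it.

Of the compounds shown here, three that share a core have been tested in a functional assay on PC-3 cells (Homo sapiens) for inhibition, read by sulforhodamine B assay; a higher number here means a weaker inhibitor of growth, a lower number a stronger inhibitor of growth. Compound 1 `COc1ccc(-c2ccc(-c3ccc(-c4nc5cc(C)ccc5[nH]4)cc3)cc2)cc1OC` gives 2560 nM in this assay, the highest number of the three. Compound 3 `COc1ccc(-c2ccc(-c3ccc(-c4nc5c(O)cccc5[nH]4)cc3)cc2)cc1OC` gives 1240 nM, and compound 2 `Oc1cccc2[nH]c(-c3ccc(-c4ccc(-c5ccccc5)cc4)cc3)nc12` gives 1240 nM.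

Two of the pairs differ in a single place. Compound 3 and compound 1 differ in the core: 5-methyl-1H-benzimidazol-2-yl in place of 4-hydroxy-1H-benzimidazol-2-yl on an aromatic carbon. The measured step is a 2.1-fold lower number from compound 1 to compound 3 (0.31 log units; beyond the scatter). Compound 3 and compound 2 differ in the outer ring: phenyl in place of 3,4-dimethoxyphenyl on an aromatic carbon. That change left the number essentially where it was, as no change at the digits printed from compound 3 to compound 2 (within the scatter).

Compound 4 `Cc1ccc2[nH]c(-c3ccc(-c4ccc(-c5ccccc5)cc4)cc3)nc2c1` has not yet been measured. It differs from compound 1 by phenyl in place of 3,4-dimethoxyphenyl on an aromatic carbon. This is the same change that turns compound 3 into compound 2, made at the same place, only now on the core of compound 1 rather than the core of compound 3. The change has been seen once, on one core, so whether the cores respond alike is not known from what is in hand.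

Because no change at the digits printed from compound 3 to compound 2 (within the scatter), the expected step is a 1.1-fold lower number from compound 1 to compound 4 (0.03 log units; within the scatter). Among the measured compounds shown here, compound 4 is therefore expected to give about 2400 nM, most likely between 1100 nM and 5200 nM, with the wide range reflecting that a single example on a different core is the only guide.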

Compound 4, concentration for 50% growth inhibition: 100000 nM
Compound 4: the middle estimate sits 42-fold (1.62 log units) below what was measured, outside the stated range (above it).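

On the core of compound 1, putting phenyl in place of 3,4-dimethoxyphenyl is far from a silent change in this assay: the step is a 39-fold higher number from compound 1 to compound 4 (1.59 log units; beyond the scatter). The same swap therefore does not carry from one core to the other in this series, and a result seen on one core proved a poor guide to the other, as the two steps side by side make plain: the same change on two cores in this assay, no change at the digits printed (within the scatter) from compound 3 to compound 2 and a 39-fold higher number (1.59 log units; beyond the scatter) from compound 1 to compound 4, 39-fold (1.59 log units) apart, beyond the scatter of two such steps What this does not show is why the cores part ways, since the comparison rests on one pair per core and cannot say whether the 5-methyl group, the 4-hydroxy group or something else about the two cores decides the outcome, nor whether the same split would appear on any further core.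

The compounds shown leave open whether an amine or a carboxylic acid on the outer ring would behave like phenyl or like 3,4-dimethoxyphenyl on the core of compound 1. They also leave open how the outer-ring swap would play out on a core bearing a chlorine atom or a longer chain in place of the 5-methyl group.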